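Exchanging the sulfanyl arm of compound 1

The compounds below may be only part of what the source reports. "The series", "measured", "known", "first", "only" and "open" are said of these compounds alone.

- compound 1 `CC(O)(CSc1ccc(F)cc1)C(=O)Nc1ccc(S(F)(F)(F)(F)F)cc1` gives 23000 nM
- compound 2 `CC(O)(CSc1ccc(C(F)(F)F)cn1)C(=O)Nc1ccc(S(F)(F)(F)(F)F)cc1` gives 19000 nM

Among the compounds with values here, in a functional assay on VCaP cells (Homo sapiens) for antiproliferative activity, read by propidium iodide staining, with a stated time of 96 h (on this read-out lower numbers stand for stronger inhibition and higher numbers for weaker inhibition), compound 1 gives 23000 nM and stands level with compound 2, the only other measured compound. Compound 3 `CC(O)(COc1ccc(C#N)cc1)C(=O)Nc1ccc(S(F)(F)(F)(F)F)cc1` alters the same arm of the molecule (4-cyanophenoxy in place of (4-fluorophenyl)sulfanyl on a saturated chain carbon, two bonds along the chain from a carbonyl carbon and an oxygen on a saturated carbon), with 4-cyanophenoxy in place of (4-fluorophenyl)sulfanyl. Within the data shown here, the one measured step that bears on this is small (a 1.2-fold lower number from compound 1 to compound 2 (0.08 log units; within the scatter)), and it swaps 4-fluorophenyl for 5-(trifluoromethyl)pyridin-2-yl on a sulfur. Among the measured compounds shown here, no measured pair tests an oxygen in place of that sulfur, or a nitrile, so the evidence is thin. In this assay no step beyond the scatter is therefore expected. The estimated step is modest (a 1.3-fold lower number from compound 1 to compound 3 (0.11 log units; within the scatter)) and remains uncertain. Compound 3 is expected near 18000 nM, with an estimated range from 6000 nM to 40000 nM for repeated measurements.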

Compound 3, half-maximal inhibitory concentration: 100000 nM
Compound 3: middle estimate off by 5.6-fold (0.74 log units), on the low side, outside the stated range (above it).
By their numbers in this assay, from the lowest: compounds 2 and 1 (each within the scatter of the next); then compound 3.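

In this assay, this arm of the molecule does not tolerate every change equally: the earlier swap of the ring on the sulfur stayed within the scatter (a 1.2-fold lower number from compound 1 to compound 2 (0.08 log units; within the scatter)), whereas 4-cyanophenoxy in place of (4-fluorophenyl)sulfanyl moves beyond it (a 4.3-fold higher number from compound 1 to compound 3 (0.64 log units; beyond the scatter)). This single step exchanges the sulfur for an oxygen and the fluorine for a nitrile at once, and it cannot tell which of the two accounts for the higher number. Nothing available here explains the rise.

Still open, from the compounds shown here alone, is whether 4-fluorophenoxy, with only the oxygen changed, or (4-cyanophenyl)sulfanyl, with only the nitrile changed, would read closer to compound 1 or to compound 3. Also open, going by these compounds, is how an amine or a longer chain on this arm would behave in this assay on the same core.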